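The source may hold more compounds than are shown below. What is called first, only, known or untested is meant among the compounds shown, and "the series" means these compounds.

Measured compounds:
compound 1 `COc1ccc(COc2ccc(OCCOCCNC3CCCC3)cc2)cc1` — 15700 nM
compound 2 `c1cc2c(cc1OCCOCCNC1CCCC1)CCCC2` — 31900 nM
compound 3 `Clc1ccc(COc2ccc(OCCOCCNC3CCCCC3)cc2)cc1` — 2650 nM

In a functional assay on SK-OV-3 cells (Homo sapiens) for inhibition, read by CCK-8 assay, with a stated time of 70 h (a higher number here means a weaker inhibitor, a lower number a stronger inhibitor), compound 1 gives 15700 nM, the second highest of the three numbers. Compound 2, with 31900 nM, is the nearest to it, and that gap lies beyond the scatter; compound 3, with 2650 nM, lies furthest from compound 1, also beyond the scatter. Compound 4 `COC(=O)c1cccc(COc2ccc(OCCOCCNC3CCCC3)cc2)c1` has not yet been measured. It differs from compound 1 by 3-(methoxycarbonyl)phenyl in place of 4-methoxyphenyl on a saturated chain carbon bound to an oxygen on an aromatic ring. Among the compounds with values here, no measured pair shows a change of this kind, so its size is open. The step from compound 1 to compound 4 is expected to be small, a 1.1-fold lower number from compound 1 to compound 4 (0.05 log units; within the scatter), with no direction beyond the scatter. Compound 4 is accordingly estimated at 14000 nM, within a range from 4500 nM to 45000 nM.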

Compound 4, half-maximal inhibitory concentration: 45500 nM
Estimate against measurement, compound 4: 3.3-fold (0.51 log units) below; measured number above the stated range.
By their numbers in this assay, from the lowest: compound 3; then compound 1; then compounds 2 and 4 (each within the scatter of the next).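

In this assay, within the data shown here, putting 3-(methoxycarbonyl)phenyl in place of 4-methoxyphenyl on a saturated chain carbon bound to an oxygen on an aromatic ring gives a 2.9-fold higher number from compound 1 to compound 4 (0.46 log units; beyond the scatter) as the first single-place comparison in this set. The aryl group at this position therefore affects the read-out, and this change modestly weakens inhibition. No measurement at hand explains the shift.

This one step changes both the substituent and where it stands on the ring, so their contributions remain unseparated. It also leaves open how a carboxylic acid or an amide in place of the methyl ester would behave.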